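The source may hold more compounds than are shown below. What is called first, only, known or untested is meant among the compounds shown, and "the series" means these compounds.

Among the measured compounds shown here, in a physicochemical assay for lipophilicity, in phosphate buffer, measured as octanol-water partition, at pH 11.5 (on this read-out lower numbers stand for lower lipophilicity and higher numbers for higher lipophilicity), two compounds have numbers so far. Compound 1 (`CCCCCCCCNC(=N)NC(=N)Nc1ccccc1`) gives 4.43 and compound 2 (`CCCCCCCCCCNC(=N)NC(=N)Nc1ccc(Cl)cc1`) gives 6.13 as the higher of the two, a gap beyond the usual scatter. Compound 3 (`CCCCCCCCCCNC(=N)NC(=N)Nc1ccccc1`) is compound 2 with a single change: hydrogen in place of chloro on an aromatic carbon in one place, hydrogen in place of chloro on an aromatic carbon. For the measured compounds named here, no measured pair shows this change alone, since compound 1 differs from compound 2 in its octyl chain as well. Compound 3 keeps the decyl chain of compound 2 and the phenyl of compound 1, so it is expected to fall between compound 1 at 4.43 and compound 2 at 6.13 on this scale. The estimated move is a number 0.73 log units lower from compound 2 to compound 3 (beyond the scatter) as a fall beyond the scatter. In this assay compound 3 is expected at 5.4 with an estimated range from 5 to 5.8 once measured.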

Compound 3, partition coefficient: 5.43
For compound 3 the middle estimate is 0.03 log units below the measured one; measured number inside the range.
By their numbers in this assay, from the lowest: compound 1; then compound 3; then compound 2.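

In this assay, the chloro on an aromatic carbon, para to a large group, can now be read as a single change: putting hydrogen in its place gives a number 0.70 log units lower from compound 2 to compound 3 (beyond the scatter), with the decyl chain held fixed. The chain can be read alone as well, since with the phenyl held fixed, going from the octyl chain to the decyl chain gives a number 1.00 log units higher from compound 1 to compound 3 (beyond the scatter). Among the compounds shown here, nothing measured so far gives a reason for the size of either step.

As far as these compounds go, each change rests on a single pair, so it remains open whether the chloro step would be the same on the octyl chain. Also open, from the compounds shown here alone, is how a fluoro or a methoxy group in that same place, or a longer chain such as dodecyl, would shift the number.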